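A few compounds are considered here, and "the series" means these few. Any claim that something is new, unique, unknown or untested is made for them only; others in the source may bear on it.

Measured so far, in an assay on isolated protein (Gallus gallus) for inhibition of transmembrane prolyl 4-hydroxylase (Homo sapiens); on this read-out lower numbers stand for stronger inhibition and higher numbers for weaker inhibition:
Compound 1, `O=C(O)c1ccc(NCc2ccc(F)cc2)cn1`, gives 31000 nM.
Compound 2, `O=C(O)c1ccc(/C=C/c2ccc(Cl)cc2)cn1`, gives 150000 nM.
Compound 3, `O=C(Nc1ccccc1)c1ccc(C(=O)O)nc1`, gives 26500 nM.

Compound 3 has the lowest number of the three in this assay. Its nearest neighbour is compound 1, whose number is only a little higher, a gap that falls within the usual scatter of repeated measurements; on these two values alone, then, compound 3 and compound 1 cannot be told apart. Compound 2 lies furthest away, with a number clearly higher than that of compound 3, a gap beyond the scatter.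

Compound 4, `O=C(Nc1ccccc1Cl)c1ccc(C(=O)O)nc1`, has not yet been measured. It differs from compound 3 in one place: chloro in place of hydrogen on an aromatic carbon. Within the data shown here, no pair of measured compounds shows what such a single swap does on this read-out, so there is no measured step to lean on. The change is small in size, a single heavy atom added to the outer ring, and the expectation is a step of modest size, most likely within the scatter or a little toward a lower number.

Compound 4 is therefore expected to give about 20000 nM in this assay, with a plausible range from 7000 nM to 60000 nM.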

Compound 4, half-maximal inhibitory concentration: 16300 nM
For compound 4 the middle estimate is 1.2-fold (0.09 log units) above the measured one; the measured number falls inside the stated range.
By their numbers in this assay, from the lowest: compounds 4, 3 and 1 (each within the scatter of the next); then compound 2.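

In this assay, chloro in place of hydrogen on an aromatic carbon, ortho to a large group, gives a 1.6-fold lower number from compound 3 to compound 4 (0.21 log units; within the scatter), so on this read-out the two compounds cannot be told apart. Among these compounds, this is the first single swap in the set that can be read directly, and it shows that one added chlorine atom at this position of the six-membered aromatic ring brings no change beyond the usual scatter of repeated measurements, neither a clear gain nor a clear loss of inhibition. Nothing available here bears on what lies behind this result.

The compounds shown leave open what a fluoro, a methyl or a methoxy group would do on the same carbon, and whether a bulkier group such as trifluoromethyl there would also leave the number within the scatter. They also leave open whether chloro on another carbon of that ring would give a step of similar size, or one large enough to read as a real difference.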